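The compounds below may be only part of what the source reports. "The series", "measured", "known", "first", "only" and "open" are said of these compounds alone.

Measured in a functional assay on MDA-MB-435 cells (Homo sapiens) for inhibition; on this read-out higher numbers stand for weaker inhibition and lower numbers for stronger inhibition:
- Compound 1 `COc1cc[nH]c1/C=C1/C(=O)Nc2ccc(F)cc21`: > 30000 nM (a limit of the assay, not a number)
- Compound 2 `COc1cc[nH]c1/C=C1\C(=O)Nc2ccc(F)c(C#C[C@H](C)O)c21`: 190 nM
- Compound 3 `COc1cc[nH]c1/C=C1\C(=O)Nc2ccc(F)c(C#C[C@H](N)CO)c21`: 320 nM

Only compound 2 and compound 3 have actual numbers, and these two lie within the scatter of each other. Compound 2 therefore has one close neighbour, while the remaining result is only a limit.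

Compound 4 `COc1cc[nH]c1/C=C1\C(=O)Nc2ccc(F)c(C#C[C@@H](N)CO)c21` has not yet been measured. It arises from compound 2 by placing 1-amino-2-hydroxyethyl in place of 1-hydroxyethyl on a triple-bonded carbon. Going by the values given here, one measured step bears on this exchange of groups: a 1.7-fold higher number from compound 2 to compound 3 (0.23 log units; within the scatter). Resting on that step, no change beyond the scatter is expected in this assay. The estimated change is a 1.8-fold higher number from compound 2 to compound 4 (0.27 log units; within the scatter), with any drift expected towards a higher number. Among the compounds with values here, no measurement yet shows what the defined stereocentre contributes, so the range is kept wide. For compound 4 the estimated value is 350 nM, with an expected range of 120 nM to 1500 nM.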

Compound 4, half-maximal inhibitory concentration: 300 nM
Compound 4: middle estimate off by 1.2-fold (0.07 log units), on the high side; the range from low to high includes it.
By their numbers in this assay, from the lowest: compounds 2, 4 and 3 (each within the scatter of the next). At a limit, above all of these: compound 1.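

In this assay, the exchange now seen a second time gives a 1.6-fold higher number from compound 2 to compound 4 (0.20 log units; within the scatter), so neither configuration of 1-amino-2-hydroxyethyl on the triple-bonded carbon separates from 1-hydroxyethyl. The new comparison concerns only a stereocentre at a saturated chain carbon and gives a 1.1-fold lower number from compound 3 to compound 4 (0.03 log units; within the scatter). At this position, therefore, the read-out does not tell the two drawn configurations of this group apart: the fact that compounds 3 and 4 differ only in the configuration as drawn

The compounds shown leave open how the stereocentre of 1-hydroxyethyl bears on the number, and what the amine and the added hydroxyl of 1-amino-2-hydroxyethyl each contribute on their own. They also leave open whether a carboxylic acid, a simple aminomethyl or a longer chain on the triple-bonded carbon would stay within the scatter of these values.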